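The source may hold more compounds than are shown below. What is called first, only, known or untested is meant among the compounds shown, and "the series" means these compounds.

Measured in a functional assay on the whole organism with Rattus norvegicus as the target; on this read-out higher numbers stand for an effect only at larger amounts of compound and lower numbers for an effect already at smaller amounts:
Compound 1 `CNc1cc(OC)c(C(=O)NC2CCN(Cc3ccccc3)C2)cc1Cl`: 0.016 mg/kg.
Compound 2 `COc1cc(NC=O)c(Cl)cc1C(=O)NC1CCN(Cc2ccccc2)C1`: 0.6 mg/kg.
Compound 3 `COc1cc(N(C)C(C)=O)c(Cl)cc1C(=O)NC1CCN(Cc2ccccc2)C1`: > 30 mg/kg, a limit.

Compound 3 gives no number, only the limit: the limit of > 30 mg/kg in this assay, at which 1 of the 3 values shown sits. Compound 4 `COc1cc(N(C)C(=O)C(F)(F)F)c(Cl)cc1C(=O)NC1CCN(Cc2ccccc2)C1` differs from it by trifluoromethyl in place of methyl on a carbonyl carbon. For the measured compounds named here, no measured step changes that group itself. The nearest steps are a 38-fold higher number from compound 1 to compound 2 (1.57 log units; beyond the scatter) and an at least 50-fold higher number from compound 2 to compound 3 (1.69 log units; beyond the scatter), both large. Compound 2 shows that a compound with an acyl group on this nitrogen can still give 0.6 mg/kg. The expected step in this assay is an at least 2.5-fold lower number from compound 3 to compound 4 (0.39 log units; beyond the scatter), toward a lower number, though a result again at the limit remains possible. For compound 4 the estimate is 12 mg/kg, with an expected range of 0.6 mg/kg to 60 mg/kg.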

Compound 4, dose for half-maximal effect: 0.3 mg/kg
Estimate against measurement, compound 4: 40-fold (1.60 log units) above; the whole stated range lies above it.
By their numbers in this assay, from the lowest: compound 1; then compounds 4 and 2 (each within the scatter of the next). At a limit, above all of these: compound 3.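

Compound 3 stands at a limit, not at a number: the limit of > 30 mg/kg in this assay, at which 1 of the 4 values shown sits. In this assay, trifluoromethyl in place of methyl on the carbonyl carbon gives an at least 100-fold lower number from compound 3 to compound 4 (2.00 log units; beyond the scatter), so an acyl group on this methylated nitrogen does not by itself abolish the effect. The two acylated forms show a 2.0-fold lower number from compound 2 to compound 4 (0.30 log units; within the scatter), while the unacylated amine stays apart with a 19-fold higher number from compound 1 to compound 4 (1.27 log units; beyond the scatter).

From the compounds shown here alone, it remains open whether a longer acyl chain, such as propionyl, or a methylsulfonyl group on this nitrogen would follow compound 4 or compound 3.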